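Chain extension in two nucleoside cores, cytotoxicity notes

A few compounds are considered here, and "the series" means these few. Any claim that something is new, unique, unknown or untested is made for them only; others in the source may bear on it.

Read-out throughout: a functional assay on L1210 cells (Mus musculus) for cytotoxicity, with a stated time of 48 h; on this read-out lower numbers stand for stronger inhibition and higher numbers for weaker inhibition.

Compound 1, `CCCC#Cc1cn([C@@H]2O[C@H](CO)[C@@H](O)[C@H](O)[C@H]2O)c(=O)nc1N`: in this assay compound 1 gives >= 250000 nM, a limit of the assay.
Compound 2, `CCCCCC#Cc1cn([C@@H]2O[C@H](CO)[C@@H](O)[C@H](O)[C@H]2O)c(=O)nc1N`: in this assay compound 2 gives >= 250000 nM, a limit of the assay.
Going by the values given here, compound 3, `CCCc1cc2cn([C@@H]3O[C@H](CO)[C@@H](O)[C@H](O)[C@H]3O)c(=O)nc2o1`: in this assay compound 3 gives 132000 nM, the one number in the set.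

Compound 1 and compound 2 share a core; the change between them is ethyl in place of hydrogen on a saturated chain carbon, three bonds along the chain from a triple-bonded carbon. The step that the two limits leave unreadable from compound 1 to compound 2 cannot be read, because both values sit at the limit of >= 250000 nM in this assay, at which 2 of the 3 values shown sit. Compound 3 carries a different core; how it differs from compound 1 is not broken down here.

Compound 4, `CCCCCc1cc2cn([C@@H]3O[C@H](CO)[C@@H](O)[C@H](O)[C@H]3O)c(=O)nc2o1`, is not yet measured. Its relation to compound 3 is ethyl in place of hydrogen on a saturated chain carbon, three bonds along the chain from an aromatic carbon. This is the same kind of change as that from compound 1 to compound 2, but the surroundings differ: in the measured pair the chain carbon lies three bonds along the chain from a triple-bonded carbon, in the new pair three bonds along the chain from an aromatic carbon. The measured pair gives no readable size for the step, so no direction can be taken from it.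

The expectation for compound 4 is an estimated step of a 1.3-fold lower number from compound 3 to compound 4 (0.12 log units; within the scatter), resting on compound 3 at 132000 nM as the only anchor and on the absence of a readable step in the measured pair. Compound 4 is estimated at 100000 nM, with a range from 25000 nM to 300000 nM, and a fair chance that only a limit is reported.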

Compound 4, half-maximal inhibitory concentration: >= 250000 nM
Compound 4: a limit, no number; the forecaster's own chance of this, stated with the estimate: 35%; at least 2.5-fold (0.39 log units) between middle value and limit.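

In this assay compound 4 gives >= 250000 nM, which is a limit of the assay and not a number. Ethyl in place of hydrogen on the core of compound 3, turning propyl into pentyl, gives an at least 1.8-fold higher number from compound 3 to compound 4 (0.27 log units; that floor lies within the scatter); this is a floor and not a measured size, and since that floor lies within the scatter, a real loss of cytotoxicity on this core is not established. The same change on the core of compound 1 cannot be read, so the notes show neither that the step carries from one core to the other nor that it differs between them, because the values gather at a single limit: the limit of >= 250000 nM in this assay, at which 3 of the 4 values shown sit.

On these data alone, whether an amine or a carboxylic acid in place of the propyl group on the core of compound 3 would give a readable value in this assay remains open, as does the effect of a shorter chain such as methyl. Going by these compounds alone, with compound 3 the only compound carrying a number, no trend with chain length can be stated for either core.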